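The source may hold more compounds than are shown below. What is called first, only, known or untested is meant among the compounds shown, and "the series" means these compounds.

In a functional assay on PC-3 cells (Homo sapiens) for antiproliferative activity, read by MTT assay, with a stated time of 72 h (on this read-out lower numbers stand for stronger inhibition and higher numbers for weaker inhibition), compound 1 `CN(C)CCn1cccc1/C=N/NC(=O)Nc1ccc(Oc2ccnc3[nH]ccc23)cc1` gives 3930 nM and compound 2 `O=C(N/N=C/c1cccn1CCCN1CCCCC1)Nc1ccc(Oc2ccnc3[nH]ccc23)cc1` gives 3580 nM, so these two stand level within the scatter. Compound 3 `CN1CCN(CCCn2cccc2/C=N/NC(=O)Nc2ccc(Oc3ccnc4[nH]ccc34)cc2)CC1` keeps the chain of compound 2 but carries 4-methylpiperazin-1-yl in place of piperidin-1-yl on a saturated chain carbon, three bonds along the chain from an aromatic nitrogen. Among the compounds with values here, the only measured step, a 1.1-fold lower number from compound 1 to compound 2 (0.04 log units; within the scatter), also exchanged the group on the chain and stayed within the scatter. One such step is thin evidence, but no change beyond the scatter is expected in this assay. The expected step is a 1.0-fold lower number from compound 2 to compound 3 (0.01 log units; within the scatter). For compound 3 the estimated value is 3500 nM, with an expected range of 1500 nM to 8000 nM.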

Compound 3, half-maximal inhibitory concentration: 3740 nM
For compound 3 the middle estimate is 1.1-fold (0.03 log units) below the measured one; the measured number falls inside the stated range.
By their numbers in this assay, from the lowest: compounds 2, 3 and 1 (each within the scatter of the next).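

In this assay, exchanging only the ring on the same 3-(piperidin-1-yl)propyl chain gives a 1.0-fold higher number from compound 2 to compound 3 (0.02 log units; within the scatter) and so stays within the scatter, which the earlier pair could not show with the chain held fixed. The exchange of dimethylamino for (4-methylpiperazin-1-yl)methyl gives a 1.1-fold lower number from compound 1 to compound 3 (0.02 log units; within the scatter) and also stays within the scatter, leaving all three compounds level. No measurement at hand explains this. Still open, from the compounds shown here alone, is whether a morpholine ring, a primary amine or a hydroxyl group at the chain end would shift the number beyond the scatter.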